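One Side Arm Changed on a Shared Core

A few compounds are considered here, and "the series" means these few. Any claim that something is new, unique, unknown or untested is made for them only; others in the source may bear on it.

Compound 1 `CNC(=O)COc1ccncc1-c1ccc2ccccc2c1` and compound 2 `COC(=O)COc1ccncc1-c1ccc2ccccc2c1` share a core and differ only in a methoxy in place of a methylamino on a carbonyl carbon. In an assay on a protein complex for inhibition of CDK8/Cyclin C (Homo sapiens), with a stated time of 1 h, tested at 10 uM (on this read-out lower numbers stand for less inhibition and higher numbers for more inhibition at the one concentration tested (going by the name of the read-out)), compound 1 gives 4%, and compound 2 gives 11%. Within the data shown here, the step of a number 7 percentage points higher from compound 1 to compound 2 (within the scatter) is within the scatter, so compound 2 carries the higher of the two numbers only nominally, with compound 1 as its sole neighbour.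

Compound 3 `CN(C)C(=O)/C=C/c1ccncc1-c1ccc2ccccc2c1` has not been measured. Against compound 2 the change is 2-(dimethylcarbamoyl)ethenyl in place of (methoxycarbonyl)methoxy on an aromatic carbon. Among the measured compounds shown here, no measured step touches this change: the single known step concerns a methoxy against a methylamino on a carbonyl carbon, not the arm joining the ring to the carbonyl. For the measured compounds named here, the only guide is that both measured numbers are low. The expected step of a number 1 percentage points lower from compound 2 to compound 3 (within the scatter) is therefore none beyond the scatter. Compound 3 is estimated to give 10% in this assay, within a range from -5% to 25%.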

Compound 3, a percentage reported as inhibition, at one concentration (the size of the read-out at that concentration, not a potency): 100%
The estimate for compound 3 lay 90 percentage points below the measured number; measured number above the stated range.
By their numbers in this assay, from the lowest: compounds 1 and 2 (each within the scatter of the next); then compound 3.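

In this assay, this position on the aromatic carbon opposite the ring nitrogen proves highly sensitive to the arm it carries, a sensitivity that the change at the end of the arm between compounds 1 and 2 did not reveal. Placing 2-(dimethylcarbamoyl)ethenyl here in place of (methoxycarbonyl)methoxy gives a number 89 percentage points higher from compound 2 to compound 3 (beyond the scatter), and placing it in place of (methylcarbamoyl)methoxy gives a number 96 percentage points higher from compound 1 to compound 3 (beyond the scatter). Nothing available explains why this change has so large an effect.

The whole arm changes at once, so the compounds shown do not separate the contribution of the ethenyl link from that of the dimethylamide end. A 2-(dimethylcarbamoyl)ethyl arm, with a saturated link, or a 2-(methylcarbamoyl)ethenyl arm, with a single methyl on the amide nitrogen, would address those two parts separately.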